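Working notes: extending the acetyl group of compound 3

The source may hold more compounds than are shown below. What is called first, only, known or untested is meant among the compounds shown, and "the series" means these compounds.

compound 1 `Cc1c2c(n3c1CCCNC[C@H](C)Nc1cc-3ccc1C(N)=O)CC(C)(C)CC2=O` gives 93 nM
compound 2 `Cc1c2c(n3c1CCN(C)C[C@@H](C)[C@H](C)Nc1cc-3ccc1C(N)=O)CC(C)(C)CC2=O` gives 27 nM
compound 3 `CC(=O)N1CCCc2c(C)c3c(n2-c2ccc(C(N)=O)c(c2)N[C@@H](C)[C@@H]1C)CC(C)(C)CC3=O` gives 27 nM

All three numbers come from a functional assay on HCT-116 cells (Homo sapiens) for antiproliferative activity (a higher number here means a weaker inhibitor, a lower number a stronger inhibitor), and no other read-out is available for the series. Within the data shown here, compound 3 (27 nM) stands level with compound 2 (27 nM), and the two share the lowest number so far. Against both, compound 1 (93 nM) reads higher, a gap beyond the usual scatter. Among the measured compounds shown here, these three compounds differ in more than one place, so no single-change step has been measured.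

The next compound to test is compound 4 `COCCC(=O)N1CCCc2c(C)c3c(n2-c2ccc(C(N)=O)c(c2)N[C@@H](C)[C@@H]1C)CC(C)(C)CC3=O`, which keeps everything in compound 3 except the acetyl group. That group becomes (2-methoxyethyl)carbonyl: methoxymethyl in place of hydrogen on a saturated chain carbon bound to a carbonyl carbon. In other words, methoxymethyl stands in place of hydrogen on a saturated chain carbon bound to a carbonyl carbon.

For the measured compounds named here, with no matched pair to draw on, the expectation rests on compound 3 (27 nM) and on the change being confined to this one chain. In this assay the expected step is small, with none beyond the scatter and a slight rise at most, and the estimate is a 1.1-fold higher number from compound 3 to compound 4 (0.05 log units; within the scatter) as the expected outcome. For compound 4 the estimated value is 30 nM with an expected range from 12 nM to 75 nM in this measurement.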

Compound 4, half-maximal inhibitory concentration: 55 nM
Estimate against measurement, compound 4: 1.8-fold (0.26 log units) below, and the stated range covers the measured number.
By their numbers in this assay, from the lowest: compounds 2 and 3 (each within the scatter of the next); then compounds 4 and 1 (each within the scatter of the next).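

In this assay, among these compounds, methoxymethyl in place of hydrogen on a saturated chain carbon bound to a carbonyl carbon gives a 2.0-fold higher number from compound 3 to compound 4 (0.31 log units; beyond the scatter), the first single-change step. The place is therefore not silent, since extending acetyl to (2-methoxyethyl)carbonyl moves the number beyond the scatter, but the step is modest and compound 4 still reads 55 nM, so this chain carbon accepts the added group at a limited cost in this assay. Nothing to hand accounts for the rise, as no measurement of any property of these compounds bears on it.

One extension cannot separate the added chain length from the ether oxygen it carries, and a butanoyl group, an all-carbon chain in the same place, would be the direct comparison with compound 4. Going by these compounds, it also remains open whether a longer chain carrying the methoxy group would raise the number further, and how a terminal amine or a carboxylic acid on this chain would read against compound 3.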